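Adding a trifluoromethyl group to compound 2

This account rests on a few compounds, and the source may have more. Where it says the series, first, only, none or still open, it means among the compounds named here.

Measured in a functional assay on HepG2 cells (Homo sapiens) for antiproliferative activity, read by MTT assay, with a stated time of 48 h (a higher number here means a weaker inhibitor, a lower number a stronger inhibitor), are these values:
Compound 1 `O=C(CN1CCCC1)Nc1ccc2ncnc(Nc3cccc(C(F)(F)F)c3)c2c1` gives 25200 nM
Compound 2 `O=C(CN1CCCC1)Nc1ccc2ncnc(Nc3ccc(Cl)cc3)c2c1` gives 18000 nM
Compound 3 `O=C(CN1CCCCC1)Nc1ccc2ncnc(Nc3ccc(Cl)cc3)c2c1` gives 16000 nM

Compound 2 lies close to both other compounds, with neither gap beyond the scatter. Compound 4 `O=C(CN1CCCC1)Nc1ccc2ncnc(Nc3ccc(Cl)c(C(F)(F)F)c3)c2c1` differs from compound 2 by trifluoromethyl in place of hydrogen on an aromatic carbon (trifluoromethyl in place of hydrogen on an aromatic carbon, ortho to a chloro group). The closest guide is a 1.4-fold lower number from compound 1 to compound 2 (0.15 log units; within the scatter) with 4-chlorophenyl in place of 3-(trifluoromethyl)phenyl, and a 1.1-fold lower number from compound 2 to compound 3 (0.05 log units; within the scatter) with piperidin-1-yl in place of pyrrolidin-1-yl bears less. No step beyond the scatter is therefore expected in this assay and the estimated step is a 1.1-fold lower number from compound 2 to compound 4 (0.05 log units; within the scatter) in size. Compound 4 is expected at 16000 nM with an estimated range from 7000 nM to 32000 nM in this measurement.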

Compound 4, half-maximal inhibitory concentration: > 100000 nM
Compound 4 was reported as a limit; the forecaster's own chance of this, stated with the estimate: 5%; at least 6.2-fold (0.79 log units) between middle value and limit.
By their numbers in this assay, from the lowest: compounds 3, 2 and 1 (each within the scatter of the next). At a limit, above all of these: compound 4.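

In this assay, compound 4 is reported only as a limit, not as a number: the limit of > 100000 nM in this assay, at which 1 of the 4 values shown sits.

Adding trifluoromethyl ortho to a chloro group gives an at least 5.5-fold higher number from compound 2 to compound 4 (0.74 log units; beyond the scatter), and adding chloro to the ring that already carries trifluoromethyl gives an at least 3.9-fold higher number from compound 1 to compound 4 (0.59 log units; beyond the scatter). The earlier steps shown here all stayed within the scatter, so only the two groups together on one ring move the number beyond it.

Going by these compounds, how far the true value lies past the limit stays open. So does whether a methyl or a fluoro at this position, alongside the chloro group, would give the same step.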